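Removing the amide from compound 2: a carboxylic acid

A few compounds are considered here, and "the series" means these few. Any claim that something is new, unique, unknown or untested is made for them only; others in the source may bear on it.

All three measured chalcones sit at the top of the scale in an ADME assay on SH-SY5Y cells (Homo sapiens) for cytotoxicity, read by MTT assay, with a stated time of 48 h; on this read-out higher numbers stand for weaker inhibition and lower numbers for stronger inhibition. Compound 1 `COc1ccc(C(=O)/C=C/c2cc(Br)c(OCc3ccccc3)c(OC)c2)c(O)c1` gives > 100000 nM, which is a limit of the assay and not a number. Compound 3 `COc1ccc(C(=O)/C=C/c2cc(OC)c(OC)c(OC)c2)c(O)c1` likewise gives only a limit, > 100000 nM. Compound 2 `COc1ccc(C(=O)/C=C/c2ccc(C(=O)N(C)c3ccccc3)cc2)c(O)c1` also returns only a limit, > 100000 nM, so its standing among the three is simply shared, because of the limit of > 100000 nM in this assay, at which 3 of the 3 values shown sit.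

Compound 4 `COc1ccc(C(=O)/C=C/c2ccc(C(=O)O)cc2)c(O)c1` differs from compound 2 by hydroxy in place of methyl(phenyl)amino on a carbonyl carbon. Within the data shown here, no measured pair shows what this kind of change does here. He expects no step beyond the scatter, with compound 4 most likely again reported only as a limit in this assay: the estimated step is a step that the limit leaves unreadable from compound 2 to compound 4. His estimate for compound 4 is 150000 nM, spanning 50000 nM to 500000 nM.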

Compound 4, half-maximal inhibitory concentration: > 100000 nM
Compound 4: only a limit was reported; the forecaster's own chance of this, stated with the estimate: 85%; the middle value does not contradict the limit.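

Like compound 2, compound 4 gives only a limit in this assay, and no step can be read between the two. The compounds shown leave open whether any change to the shared core would yield a measurable value.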